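Azetidine Amide in a Cathepsin S Nitrile Series

The source may hold more compounds than are shown below. What is called first, only, known or untested is meant among the compounds shown, and "the series" means these compounds.

Measured so far:
compound 1, `N#CCNC(=O)[C@@H]1C[C@@H](S(=O)(=O)c2ccccc2C(F)(F)F)C[C@H]1C(=O)N1CCOCC1`, 0.9 nM;
compound 2, `N#CC1(NC(=O)[C@@H]2C[C@@H](S(=O)(=O)c3ccccc3)C[C@H]2C(=O)N2CC3CCC(C2)O3)CC1`, 1 nM;
compound 3, `N#CC1(NC(=O)[C@@H]2C[C@@H](S(=O)(=O)c3ccccc3)C[C@H]2C(=O)N2CCCC2)CC1`, 2 nM.

These three compounds were tested in an assay on isolated protein for inhibition of cathepsin S (Homo sapiens), read by fluorescence, with a stated time of 20 min; a higher number here means a weaker inhibitor, a lower number a stronger inhibitor. Compound 2 sits close to both neighbours: compound 1 and compound 3 differ from it only within the scatter. Compound 4, `N#CC1(NC(=O)[C@@H]2C[C@@H](S(=O)(=O)c3ccccc3)C[C@H]2C(=O)N2CCC2)CC1`, differs from compound 2 at the amide: a group of 4 heavy atoms (3 carbon, 1 nitrogen; one four-membered non-aromatic ring with 1 hetero atom) in place of a group of 8 heavy atoms (6 carbon, 1 nitrogen, 1 oxygen; one five-membered non-aromatic ring with 1 hetero atom, one six-membered non-aromatic ring with 2 hetero atoms), on a carbonyl carbon. Among the compounds with values here, the one step that bears on this change is a 2.0-fold higher number from compound 2 to compound 3 (0.30 log units; within the scatter), where a smaller ring amine replaced the same group at the same carbonyl and the number stayed within the scatter. The azetidin-1-yl ring is smaller still, so the expected step of a 2.0-fold higher number from compound 2 to compound 4 (0.30 log units; within the scatter) is small, with a lean toward a slightly higher number. Compound 4 is estimated at 2 nM, within 0.7 nM to 6 nM.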

Compound 4, half-maximal inhibitory concentration: 10 nM
For compound 4 the middle estimate is 5.0-fold (0.70 log units) below the measured one; measured number outside the range, above it.
By their numbers in this assay, from the lowest: compounds 1, 2 and 3 (each within the scatter of the next, the first and the last beyond it); then compound 4.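

Making the amine on the carbonyl carbon smaller was not harmless all the way down: azetidin-1-yl gives a 10-fold higher number from compound 2 to compound 4 (1.00 log units; beyond the scatter), and a 5.0-fold higher number from compound 3 to compound 4 (0.70 log units; beyond the scatter). The tolerance seen with pyrrolidin-1-yl therefore does not extend to the four-membered ring, so ring size at this position does matter. Nothing available here explains why this ring weakens inhibition.

On these data alone, whether an open-chain dimethylamino group on the same carbonyl carbon would behave like pyrrolidin-1-yl or like azetidin-1-yl remains open. So does whether azetidin-1-yl would cost as much on the core of compound 1.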